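Benzyl in Place of Hydrogen: An Expected Cytotoxicity Value

A few compounds are considered here, and "the series" means these few. Any claim that something is new, unique, unknown or untested is made for them only; others in the source may bear on it.

Two compounds have been measured in a functional assay on MCF7 cells (Homo sapiens) for cytotoxicity, read by MTT assay, with a stated time of 72 h; on this read-out lower numbers stand for stronger inhibition and higher numbers for weaker inhibition:
compound 1 `COC(=O)c1ccc(/C=C/C(=O)c2cc3cc(O)ccc3oc2=O)cc1` gives 1300 nM;
compound 2 `COc1cccc(/C=C/C(=O)c2cc3cc(O)ccc3oc2=O)c1OC` gives 8800 nM.

Compound 2 stands at the higher of the two numbers, and compound 1 lies clearly apart from it, a gap beyond the usual scatter. Compound 3 `COc1cccc(/C=C/C(=O)c2cc3cc(OCc4ccccc4)ccc3oc2=O)c1OC` keeps everything in compound 2 and differs in one place: benzyl in place of hydrogen on an oxygen on an aromatic ring. Among the measured compounds shown here, no measured pair shows this change, so its effect cannot be read from the numbers at hand; the two measured compounds differ elsewhere and say nothing about it. The step expected in this assay is therefore modest and of uncertain direction, a 1.1-fold higher number from compound 2 to compound 3 (0.06 log units; within the scatter), leaning only slightly toward a higher number. Compound 3 is expected to give about 10000 nM in this assay, with a likely range from 3000 nM to 35000 nM.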

Compound 3, half-maximal inhibitory concentration: 21300 nM
Beside the measured number, compound 3's estimate is 2.1-fold (0.33 log units) below it; measured number inside the range.
By their numbers in this assay, from the lowest: compound 1; then compound 2; then compound 3.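

In this assay, among the compounds shown here, the change from hydroxy to benzyloxy gives a 2.4-fold higher number from compound 2 to compound 3 (0.38 log units; beyond the scatter), the first measured reading at this position. It shows that the oxygen on the aromatic ring is not indifferent to what it carries: in this one pair, hydrogen gives the lower number and benzyl the higher, with the step beyond the usual scatter. Nothing available accounts for this rise.

On these data alone, whether the step belongs to benzyl itself or would follow any replacement of the hydrogen stays open; an ethyl group or an aminoethyl chain on the same oxygen would help separate the two. Also open, as far as these compounds go, is whether benzyl would move the number the same way on the core of compound 1, which gives 1300 nM with its hydroxy group free.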